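The source may hold more compounds than are shown below. What is called first, only, known or untested is meant among the compounds shown, and "the series" means these compounds.

Of the compounds shown here, two have been measured so far. Compound 1 `Cc1cc(-c2cnc(NCc3c(F)ccc4c3CCO4)c3cn[nH]c(=O)c23)n(C)n1` was tested in an ADME assay on microsomes from liver (Homo sapiens) for metabolic stability, read by LC-MS, using NADPH, with stated times of 5 min and 30 min, tested at 1 uM (on this read-out lower numbers stand for slow clearance and higher numbers for fast clearance), where compound 1 gives 24 mL.min-1.g-1. Compound 2 `Fc1ccc2c(c1CNc1ncc(Oc3ccccc3)c3nncn13)CCO2`, which keeps the same side chain on a different core and carries a phenoxy group, gives 18 mL.min-1.g-1 in this assay. The two numbers sit within the usual scatter of each other, so on this evidence compound 2 stands simply as one of two close readings, not apart from compound 1.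

Compound 3 `CN(c1ncco1)c1cnc(NCc2c(F)ccc3c2CCO3)n2cnnc12` has not yet been measured. It keeps the core and side chain of compound 2 and differs in one place: methyl(1,3-oxazol-2-yl)amino in place of phenoxy on an aromatic carbon. The phenoxy group leaves and methyl(1,3-oxazol-2-yl)amino enters, on an aromatic carbon of a six-membered aromatic ring with 2 nitrogen, para to a large group. Going by the values given here, no measured pair shows what such a swap does to clearance here, so the expectation rests on compound 2 alone. The expected step, a 1.2-fold lower number from compound 2 to compound 3 (0.08 log units; within the scatter), is no larger than the scatter in either direction. Compound 3 is therefore estimated at 15 mL.min-1.g-1, with a likely range from 7 mL.min-1.g-1 to 32 mL.min-1.g-1.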

Compound 3, intrinsic clearance in microsomes: 11 mL.min-1.g-1
Estimate against measurement, compound 3: 1.4-fold (0.13 log units) above; the measured number falls inside the stated range.
By their numbers in this assay, from the lowest: compounds 3, 2 and 1 (each within the scatter of the next, the first and the last beyond it).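

Going by these compounds alone, the first direct reading on this position in this assay is a 1.6-fold lower number from compound 2 to compound 3 (0.21 log units; within the scatter) when methyl(1,3-oxazol-2-yl)amino takes the place of phenoxy on an aromatic carbon, para to a large group. This pair shows that a six-membered aromatic ring of carbon only can give way to a five-membered aromatic ring with 2 hetero atoms, and a group with 1 hydrogen-bond acceptor to one with 3, while the two clearance readings stay too close to tell apart. Nothing measured here ties this result to any particular feature of either group.

One swap between two groups of equal heavy-atom count leaves open how far this position can be pushed, for instance with a small methoxy group, a saturated amine such as morpholine, or a carboxylic acid. Also open, on these data alone, is whether methyl(1,3-oxazol-2-yl)amino in place of phenoxy would read the same way on a different core, such as the core of compound 1.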